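The source may report more compounds than this note shows. Statements on the series, on what has been measured and on what is new or still open speak of the compounds shown alone.

Measured in an ADME assay on K562 cells (Homo sapiens) for cytotoxicity, with a stated time of 72 h; on this read-out lower numbers stand for stronger inhibition and higher numbers for weaker inhibition:
Compound 1 `Oc1ccccc1CNc1ncnc2c1ncn2C1CCCCO1`: > 100000 nM (a limit)
Compound 2 `COc1cccc(CNc2ncnc3c2ncn3C2CCCCO2)c1`: 61000 nM

For the measured compounds named here, compound 2, at 61000 nM, holds the only actual number. Compound 3 `COc1cccc(CNc2ncnc3c2ncn3C2CCCCO2)c1O` differs from compound 2 by hydroxy in place of hydrogen on an aromatic carbon, ortho to a methoxy group. Going by the values given here, the one measured step, an at least 1.6-fold lower number from compound 1 to compound 2 (0.21 log units; that floor lies within the scatter), puts 3-methoxyphenyl in place of 2-hydroxyphenyl, and its floor lies within the scatter. A slight move towards weaker inhibition is therefore expected, but none clearly beyond the scatter. The expected change is a 1.1-fold higher number from compound 2 to compound 3 (0.06 log units; within the scatter). For compound 3 the estimate is 70000 nM, with an expected range of 30000 nM to 160000 nM.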

Compound 3, half-maximal inhibitory concentration: > 100000 nM
Compound 3: no number, only a limit; the forecaster's own chance of this, stated with the estimate: 40%; at least 1.4-fold (0.15 log units) between middle value and limit.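

In this assay hydroxy in place of hydrogen on an aromatic carbon, ortho to a methoxy group, gives an at least 1.6-fold higher number from compound 2 to compound 3 (0.21 log units; that floor lies within the scatter) at this position. The step from compound 1 to compound 3 cannot be read, since both values are limits. Only a floor is readable for the hydroxy change, so it is not shown to exceed the scatter, and its full size stays hidden because of the assay ceiling: the limit of > 100000 nM in this assay, at which 2 of the 3 values shown sit.

On these data alone, whether an amine or a carboxylic acid in place of this hydroxy gives a number stays open. As far as these compounds go, the effect of a longer chain in place of the methoxy group is also open.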